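The source may report more compounds than this note shows. Statements on the series, on what has been measured and on what is new or still open speak of the compounds shown alone.

Measured so far in a functional assay on Ehrlich cells (Mus musculus) for cytotoxicity, tested at 25 ug/mL; on this read-out lower numbers stand for a weaker effect and higher numbers for a stronger effect at the one concentration tested:

compound 1 `COc1cc(N2C(N)=C(C#N)C(c3cccc([N+](=O)[O-])c3)C3=C2CC(C)(C)CC3=O)cc(OC)c1OC` gives 20%
compound 2 `COc1ccccc1C1C(C#N)=C(N)N(c2cc(OC)c(OC)c(OC)c2)C2=C1C(=O)CC(C)(C)C2` gives 65%

Compound 2 stands highest of the two numbers in this assay; its nearest neighbour is compound 1, which sits a large step lower: a number 45 percentage points higher from compound 1 to compound 2 (beyond the scatter). That step is the only one measured, and it turns on the same saturated ring carbon as the change considered next.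

Compound 3 `COc1cc(N2C(N)=C(C#N)C(c3ccc(C)cc3)C3=C2CC(C)(C)CC3=O)cc(OC)c1OC` is not yet measured. It differs from compound 2 by 4-methylphenyl in place of 2-methoxyphenyl on a saturated ring carbon. So the group leaving is the 2-methoxyphenyl that entered in the one measured step, and a 4-methylphenyl comes in its place. For the measured compounds named here, no step with 4-methylphenyl at this carbon has been measured, so the measured step fixes only that this position can move the read-out by a large amount in either direction, not where the new group will land.

With that, compound 3 is estimated at 45%, in a range from 15% to 80%. The expected step is therefore a number 20 percentage points lower from compound 2 to compound 3 (beyond the scatter), an estimate of a moderate fall whose range also covers no change beyond the scatter.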

Compound 3, a percentage reported as activity, at one concentration (the size of the read-out at that concentration, not a potency): 50%
Compound 3: the middle estimate sits 5 percentage points below what was measured; low and high end bracket the measured number.
By their numbers in this assay, from the lowest: compound 1; then compound 3; then compound 2.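

At this saturated ring carbon, a third aryl group now gives an intermediate level in this assay with a number 15 percentage points lower from compound 2 to compound 3 (beyond the scatter) on the loss of 2-methoxyphenyl and a number 30 percentage points higher from compound 1 to compound 3 (beyond the scatter) on the loss of 3-nitrophenyl. The position therefore gives more than two levels of read-out, and the high value of compound 2 does not carry over unchanged to every group that replaces 3-nitrophenyl, although 4-methylphenyl, with no hydrogen-bond acceptor, still stands clearly above the 3-nitrophenyl of compound 1. Nothing at hand accounts for these differences in terms of mechanism.

The change from compound 2 to compound 3 alters both the substituent and its numbered place on the phenyl, so 4-methoxyphenyl or 2-methylphenyl at this carbon would be needed to tell those two changes apart, and plain phenyl would give the reference for all three groups. The compounds shown also leave open how far this order holds for a group with an amine on the phenyl, and whether it persists when the 3,4,5-trimethoxyphenyl group shared by all three compounds is replaced.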